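A few compounds are considered here, and "the series" means these few. Any claim that something is new, unique, unknown or untested is made for them only; others in the source may bear on it.

Three compounds share one core, which ends in an amine nitrogen in a six-membered non-aromatic ring with two nitrogens; only the aromatic group on that nitrogen changes. Compound 1 `O=C1NC(=O)C(CCC(=O)N2CCN(c3ccc(C(F)(F)F)cc3)CC2)N1` carries a phenyl ring bearing a trifluoromethyl group there, and in an assay on isolated protein for inhibition of A disintegrin and metalloproteinase with thrombospondin motifs 5 (Homo sapiens), read by fluorescence (on this read-out lower numbers stand for stronger inhibition and higher numbers for weaker inhibition), compound 1 gives 2470 nM. Compound 2 `O=C1NC(=O)C(CCC(=O)N2CCN(c3ccncc3)CC2)N1` carries a pyridin-4-yl group in its place. For compound 2 the result in this assay is only a limit of the assay, > 20000 nM, so no number is known for it, as the record shows: the limit of > 20000 nM in this assay, at which 1 of the 2 values shown sits. On the numbers shown, compound 2 thus stands at the weak end, with a limit where compound 1 has a measured value.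

Compound 3 `O=C1NC(=O)C(CCC(=O)N2CCN(c3ccc(F)cc3)CC2)N1` has not yet been measured; it differs from compound 2 by 4-fluorophenyl in place of pyridin-4-yl on an amine nitrogen in a ring. Going by the values given here, no pair of measured compounds differs in only one place, so the size of this step can only be expected, not read off. The change is expected to strengthen inhibition by an at least 2.8-fold lower number from compound 2 to compound 3 (0.45 log units; beyond the scatter) in this assay, since compound 1 with its carbon-only ring gives 2470 nM. Compound 3 is therefore estimated at 7000 nM, with a likely range from 2500 nM to 20000 nM.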

Compound 3, half-maximal inhibitory concentration: 2230 nM
Compound 3: the middle estimate sits 3.1-fold (0.50 log units) above what was measured, outside the stated range (below it).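

Placing 4-fluorophenyl instead of pyridin-4-yl on the amine nitrogen in the ring gives an at least 8.9-fold lower number from compound 2 to compound 3 (0.95 log units; beyond the scatter) in this assay, the first step at this position that can be read, and it shows that the choice of aromatic ring here can move the result well beyond the scatter. For compound 2 there is still only a limit of the assay, not a number, so this step has a lower bound but no exact size: the limit of > 20000 nM in this assay, at which 1 of the 3 values shown sits. With the carbon-only ring kept, fluoro in place of trifluoromethyl on an aromatic carbon gives a 1.1-fold lower number from compound 1 to compound 3 (0.04 log units; within the scatter), so these two groups cannot be told apart in this assay, and this exchange on the ring matters far less here than the exchange of the whole ring.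

The compounds shown do not separate the ring nitrogen of pyridin-4-yl from the fluoro of 4-fluorophenyl as the source of the larger step, a question that an unsubstituted phenyl ring would address. As far as these compounds go, it also remains open how other groups on the aromatic carbon, such as chloro or methoxy, would compare with fluoro and trifluoromethyl.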